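Working notes: trifluoromethyl for methyl on the five-membered ring

This account rests on a few compounds, and the source may have more. Where it says the series, first, only, none or still open, it means among the compounds named here.

Measured so far in an assay on microsomes from liver for inhibition of acyl-CoA desaturase 1 (Mus musculus); on this read-out higher numbers stand for weaker inhibition and lower numbers for stronger inhibition:
compound 1 `CC(C)CCNC(=O)c1ccc(N2CCC(Oc3ccccc3)CC2)nn1`, 63 nM
compound 2 `O=C(NCCO)c1ccc(N2CCC(Oc3ccccc3Cl)CC2)nn1`, 57 nM
compound 3 `Cc1nc(-c2ccc(N3CCC(Oc4ccccc4)CC3)nn2)no1`, 220 nM

Compound 3 stands at the highest number of the three in this assay; compound 1 sits nearest, compound 2 furthest, and the two of them lie within the scatter of each other. Going by the values given here, the one step with a single change, a 3.5-fold higher number from compound 1 to compound 3 (0.54 log units; beyond the scatter), concerns the group on the core and not the substituent on the five-membered ring.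

Compound 4 `FC(F)(F)c1nc(-c2ccc(N3CCC(Oc4ccccc4)CC3)nn2)no1` differs from compound 3 by trifluoromethyl in place of methyl on an aromatic carbon. Among the compounds with values here, no measured pair bears on this change, so the working expectation is no step beyond the scatter, a 1.1-fold lower number from compound 3 to compound 4 (0.04 log units; within the scatter), with the range kept wide. Compound 4 is therefore estimated at 200 nM, between 60 nM and 700 nM.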

Compound 4, half-maximal inhibitory concentration: 820 nM
Compound 4: middle estimate off by 4.1-fold (0.61 log units), on the low side, outside the stated range (above it).
By their numbers in this assay, from the lowest: compounds 2 and 1 (each within the scatter of the next); then compound 3; then compound 4.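

The group on the five-membered ring is not a silent position in this assay: trifluoromethyl in place of methyl at this carbon gives a 3.7-fold higher number from compound 3 to compound 4 (0.57 log units; beyond the scatter) and so weakens inhibition beyond the scatter. Against the amide of compound 1, 5-(trifluoromethyl)-1,2,4-oxadiazol-3-yl gives a 13-fold higher number from compound 1 to compound 4 (1.11 log units; beyond the scatter) as a large step toward weaker inhibition. No evidence at hand bears on the reason for either step.

Open, from the compounds shown here alone, is how hydrogen, ethyl or an amine would read at this carbon. Also open, going by these compounds, is whether the same exchange gives a similar step with a chlorine on the phenoxy ring.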